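Methoxy to ethoxy: from compound 3 toward compound 4

The source may hold more compounds than are shown below. What is called first, only, known or untested is meant among the compounds shown, and "the series" means these compounds.

Three members of the series have been read in a functional assay on MCF7 cells (Homo sapiens) for cytotoxicity, read by MTT assay, with a stated time of 48 h; a lower number here means a stronger inhibitor, a higher number a weaker inhibitor. Compound 1 `CCOc1ccc(NC(=O)c2cn(-c3ccccc3)nc2-c2ccccc2)cc1` gives 880 nM. Compound 2 `CCOc1ccc(NC(=O)c2cn(-c3ccccc3)nc2-c2ccc(C)cc2)cc1` gives 1030 nM, and compound 3 `COc1ccc(NC(=O)c2cn(-c3ccccc3)nc2-c2ccc(Cl)cc2)cc1` gives 1550 nM, the highest of the three numbers, though its gaps to compound 2 and to compound 1 both sit within the scatter. Going by the values given here, the only single-point step among the measured compounds, a 1.2-fold higher number from compound 1 to compound 2 (0.07 log units; within the scatter), is within the scatter as well.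

Compound 4 `CCOc1ccc(NC(=O)c2cn(-c3ccccc3)nc2-c2ccc(Cl)cc2)cc1` is still unmeasured. It differs from compound 3 by methyl in place of hydrogen on a saturated chain carbon bound to an oxygen on an aromatic ring, that is methoxy to ethoxy. Among the compounds with values here, no measured pair isolates this change: compound 1 and compound 2 carry ethoxy and compound 3 carries methoxy, but each of them also differs elsewhere, so the alkoxy change has not been read on its own. What the series does show is narrow, because a 1.2-fold higher number from compound 1 to compound 2 (0.07 log units; within the scatter) stayed within the scatter, and because compound 1 at 880 nM and compound 3 at 1550 nM differ only within the scatter. The expected step is therefore a 1.3-fold lower number from compound 3 to compound 4 (0.11 log units; within the scatter), nothing beyond the scatter. Compound 4 is estimated at 1200 nM, with a range from 600 nM to 2500 nM.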

Compound 4, half-maximal inhibitory concentration: 560 nM
The estimate for compound 4 lay 2.1-fold (0.33 log units) above the measured number, outside the stated range (below it).
By their numbers in this assay, from the lowest: compounds 4, 1, 2 and 3 (each within the scatter of the next, the first and the last beyond it).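

In this assay, going by these compounds alone, the step for 4-methoxyphenyl to 4-ethoxyphenyl, a 2.8-fold lower number from compound 3 to compound 4 (0.44 log units; beyond the scatter), is the first step to lie beyond the scatter, so a single methyl on the saturated chain carbon bound to an oxygen on an aromatic ring can shift the number in a way the earlier compounds did not show. With ethoxy held constant, chloro is not separated from either alternative on the aromatic carbon: chloro in place of methyl gives a 1.8-fold lower number from compound 2 to compound 4 (0.26 log units; within the scatter), and chloro in place of hydrogen gives a 1.6-fold lower number from compound 1 to compound 4 (0.20 log units; within the scatter), both within the scatter. Nothing available offers an explanation for the methoxy to ethoxy step.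

The compounds shown contain only one matched methoxy and ethoxy pair, and it carries chloro, so it remains open whether the same change would hold with hydrogen or methyl on that aromatic carbon. Also open, on these data alone, is how the number would respond if the chain grew beyond ethyl, as in propoxy or butoxy, or if it ended in an amine or a carboxylic acid.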